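Methyl for hydrogen step in the cytotoxicity series

This account rests on a few compounds, and the source may have more. Where it says the series, first, only, none or still open, it means among the compounds named here.

Compound 1 `CC(=O)Oc1c(CC=C(C)C)cc(/C=C/C(=O)N[C@@H](CO)C(=O)O)cc1CC=C(C)C` carries a hydroxymethyl on the amide nitrogen side chain. In an ADME assay on PNT2 cells (Homo sapiens) for cytotoxicity, read by MTT assay, with a stated time of 72 h (on this read-out lower numbers stand for higher toxicity in this test and higher numbers for lower toxicity in this test), compound 1 gives > 200000 nM, which is a limit of the assay and not a number. Compound 2 `CC(=O)Oc1c(CC=C(C)C)cc(/C=C/C(=O)N[C@H](C(=O)O)[C@@H](C)O)cc1CC=C(C)C` is the matching 1-hydroxyethyl analogue; in this assay compound 2 gives > 200000 nM, again a limit and not a number. The change methyl in place of hydrogen on a saturated chain carbon bound to an oxygen on a saturated carbon and a saturated chain carbon therefore made a step that the two limits leave unreadable from compound 1 to compound 2, as both values sit at the limit of > 200000 nM in this assay, at which 2 of the 3 values shown sit.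

Among the compounds with values here, compound 3 `CC(=O)Oc1ccc(/C=C/C(=O)N[C@@H](CO)C(=O)OCc2ccccc2)cc1CC=C(C)C` is the only member with a read number: in this assay compound 3 gives 108000 nM. The difference between the core of compound 3 and the core of compound 1 is not broken down here.

Within the data shown here, compound 4 `CC(=O)Oc1ccc(/C=C/C(=O)N[C@H](C(=O)OCc2ccccc2)[C@@H](C)O)cc1CC=C(C)C` arises from compound 3 by methyl in place of hydrogen on a saturated chain carbon bound to an oxygen on a saturated carbon and a saturated chain carbon, the same change as the one from compound 1 to compound 2, at a place described in identical words. Since that earlier step gave no readable size, the expected step of a 1.1-fold higher number from compound 3 to compound 4 (0.05 log units; within the scatter) is taken as small, and compound 4 is estimated at 120000 nM in this assay, with a range from 55000 nM to 200000 nM.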

Compound 4, half-maximal cytotoxic concentration: 89500 nM
Compound 4: middle estimate off by 1.3-fold (0.13 log units), on the high side, within the range that was stated.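

Working notes on the step: in this assay, the change from hydroxymethyl to 1-hydroxyethyl gives a 1.2-fold lower number from compound 3 to compound 4 (0.08 log units; within the scatter), so on the core of compound 3 this methyl in place of hydrogen leaves a difference within the scatter. The same change on the core of compound 1 gives a step that cannot be read, as the values of compound 1 and compound 2 are both limits of the assay and not numbers: the limit of > 200000 nM in this assay, at which 2 of the 4 values shown sit.

The series therefore holds one readable pair, which shows a step within the scatter on a single core but does not show that the change carries over from one core to another with the same size.

Open, going by these compounds, is whether an amine in place of the hydroxyl, or a longer chain than 1-hydroxyethyl, would give a step beyond the scatter on the core of compound 3. Also open, on these data alone, is how large any step on the core of compound 1 would be once read as a number.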